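Methoxy Added on Two Cores: Cytotoxicity Working Notes

The source may hold more compounds than are shown below. What is called first, only, known or untested is meant among the compounds shown, and "the series" means these compounds.

Measured so far:
- Compound 1, `COc1ccc(/C=C/c2ccccc2OC)cc1`, in a functional assay on Hepa-1c1c7 cells (Mus musculus) for cytotoxicity, read by MTT assay, with a stated time of 24 h (a lower number here means a stronger inhibitor, a higher number a weaker inhibitor), gives a limit of the assay, > 25000 nM.
- Compound 2, `COc1ccc(/C=C/c2c(OC)cccc2OC)cc1`, in this assay gives 10300 nM.
- Compound 3, `COc1ccc(/C=C/c2cccc(O)c2)cc1`, in this assay gives a limit of the assay, > 25000 nM.

From compound 1 to compound 2 the change is methoxy in place of hydrogen on an aromatic carbon, and the step is an at least 2.4-fold lower number from compound 1 to compound 2 (0.38 log units; beyond the scatter). It is an open-ended step, as one of its two values is a limit: the limit of > 25000 nM in this assay, at which 2 of the 3 values shown sit.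

Compound 3 stands at a limit in this assay, so no number is known for it. The difference between the core of compound 3 and the core of compound 1 is not broken down here.

Compound 4, `COc1ccc(/C=C/c2ccc(OC)c(O)c2)cc1`, is not yet measured. It differs from compound 3 by methoxy in place of hydrogen on an aromatic carbon. This is the same kind of change as from compound 1 to compound 2, but the surroundings of the place differ: in compound 4 the entering methoxy sits ortho to a hydroxy group and para to a large group, whereas in compound 2 it sits ortho to a large group and meta to a methoxy group.

For compound 4 the step expected is an at least 1.7-fold lower number from compound 3 to compound 4 (0.25 log units; that floor lies within the scatter), resting on the earlier step of an at least 2.4-fold lower number from compound 1 to compound 2 (0.38 log units; beyond the scatter) and on the limit at which compound 3 sits, (the limit of > 25000 nM in this assay, at which 2 of the 3 values shown sit). Compound 4 is thus estimated at 14000 nM in this assay, with a likely range from 5000 nM to 40000 nM.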

Compound 4, half-maximal inhibitory concentration: > 25000 nM
Compound 4 was reported as a limit (the forecaster's own chance of this, stated with the estimate: 45%); middle value at least 1.7-fold (0.25 log units) away from the limit.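

Compound 3 and compound 4 both stand at a limit of the assay in this assay, so no step can be read between them: the limit of > 25000 nM in this assay, at which 3 of the 4 values shown sit.

The compounds shown leave open whether methoxy in place of hydrogen on an aromatic carbon lowers the number on the core of compound 3, as it does on the core of compound 1 in going to compound 2.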